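Compound 3 to compound 4: chloro in place of cyano

The compounds below may be only part of what the source reports. "The series", "measured", "known", "first", "only" and "open" are said of these compounds alone.

In an ADME assay on the whole organism (Rattus norvegicus, strain Sprague-Dawley), read by LC-MS (a higher number here means that the compound lasts longer, a lower number that the compound disappears faster), compound 1 `N#Cc1ccc(S(=O)(=O)[C@H]2CN(S(=O)(=O)c3ccc(Cl)cc3Cl)C[C@@]2(O)CO)cc1` gives 1.7 h, compound 2 `N#Cc1ccc(S(=O)(=O)[C@H]2CN(S(=O)(=O)c3ccc(Cl)cc3C#N)C[C@@]2(O)CO)cc1` gives 0.5 h and compound 3 `N#Cc1ccc(S(=O)(=O)[C@H]2CN(S(=O)(=O)c3ccc(C#N)cc3Cl)C[C@@]2(O)CO)cc1` gives 1 h. Compound 3 lies within the scatter of both others, with a 1.7-fold lower number from compound 1 to compound 3 (0.23 log units; within the scatter) and a 2.0-fold higher number from compound 2 to compound 3 (0.30 log units; within the scatter). Compound 4 `N#Cc1ccc(S(=O)(=O)N2C[C@H](S(=O)(=O)c3ccc(Cl)cc3)[C@](O)(CO)C2)c(Cl)c1` has chloro in place of cyano on an aromatic carbon, the change from 4-cyanophenyl to 4-chlorophenyl (chloro in place of cyano on an aromatic carbon). Among the measured compounds shown here, no measured step covers this site. The closest evidence is the reverse swap elsewhere in the molecule, cyano in place of chloro, with a 3.4-fold lower number from compound 1 to compound 2 (0.53 log units; beyond the scatter) and the smaller step to compound 3 given above. A slight upward lean is expected in this assay, but nothing beyond the scatter. The estimated step is a 1.5-fold higher number from compound 3 to compound 4 (0.18 log units; within the scatter). The estimate for compound 4 is 1.5 h, with an expected range of 0.7 h to 3 h.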

Compound 4, mean residence time: 1.6 h
Compound 4: middle estimate off by 1.1-fold (0.03 log units), on the low side, and the stated range covers the measured number.
By their numbers in this assay, from the lowest: compounds 2, 3, 4 and 1 (each within the scatter of the next, the first and the last beyond it).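

Among the compounds shown here, at the aromatic carbon para to a large group, the first reading of this swap gives a 1.6-fold higher number from compound 3 to compound 4 (0.20 log units; within the scatter), so this assay does not separate chloro from cyano at this site. The swap also does not depend measurably on where it sits in the series, as the comparison across the two cores shows: the same change on two cores in this assay, a 3.4-fold lower number (0.53 log units; beyond the scatter) from compound 1 to compound 2 and a 1.6-fold lower number (0.20 log units; within the scatter) from compound 4 to compound 3, 2.1-fold (0.33 log units) apart, within the scatter of two such steps

The compounds shown carry only chloro or cyano at this site, so the outcome with an amine, a carboxylic acid or a methoxy group there remains open. From the compounds shown here alone, what sets the residence time of the series also remains open.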